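The source may hold more compounds than are shown below. What is called first, only, known or untested is meant among the compounds shown, and "the series" means these compounds.

Compound 1 `CCc1ccc(NC(=O)c2cccc(/C=C3\CC(=O)N(c4ccccc4)C3=O)c2)cc1` shows no measurable cytotoxicity: in an ADME assay on HCT-116 cells (Homo sapiens) for cytotoxicity, read by MTT assay, with a stated time of 72 h (a higher number here means a weaker inhibitor, a lower number a stronger inhibitor), compound 1 gives only a limit, > 100000 nM. Compound 2 `Cc1ccc(N2C(=O)C/C(=C\c3cccc(C(=O)Nc4cccc(F)c4)c3)C2=O)cc1` likewise reaches only a limit in this assay, > 100000 nM. For the measured compounds named here, both results coincide with the limit of > 100000 nM in this assay, at which 2 of the 2 values shown sit, so no measured step between two numbers exists. Compound 3 `Cc1cccc(NC(=O)c2cccc(/C=C3\CC(=O)N(c4ccccc4)C3=O)c2)c1` carries 3-methylphenyl in place of 4-ethylphenyl on an amide-type nitrogen. No shift beyond the scatter is expected for the step from compound 1 to compound 3, a number no higher from compound 1 to compound 3 (the limit leaves the size open). Compound 3 is accordingly estimated at 100000 nM, within 50000 nM to 300000 nM, and will most probably again be reported only as a limit in this assay.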

Compound 3, half-maximal inhibitory concentration: > 100000 nM
Compound 3: no number, only a limit; the forecaster's own chance of this, stated with the estimate: 85%; the middle value lies on the limit itself.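

For the compounds shown here, compound 3, like compound 1, gives only a limit in this assay, so no step from compound 1 to compound 3 can be read: the limit of > 100000 nM in this assay, at which 3 of the 3 values shown sit. The compounds shown leave open whether any structural change in this series would give a measurable value in this assay.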